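Swapping the sulfonyl aryl group in a cytotoxic series

This account rests on a few compounds, and the source may have more. Where it says the series, first, only, none or still open, it means among the compounds named here.

Compound 1 `O=S(=O)(NCCCNc1nccc(-c2[nH]c(-c3ccccc3)nc2-c2ccc(F)c(O)c2)n1)c1cccc(F)c1` is the reference point. In a functional assay on LOX IMVI cells (Homo sapiens) for cytotoxicity, read by MTT assay, with a stated time of 24 h (a higher number here means a weaker inhibitor, a lower number a stronger inhibitor), compound 1 gives 7890 nM. Compound 2 `Cc1ccc(S(=O)(=O)NCCCNc2nccc(-c3[nH]c(-c4ccccc4)nc3-c3ccc(F)c(O)c3)n2)cc1` carries one change, (4-methylphenyl in place of 3-fluorophenyl on a sulfonyl sulfur); in this assay compound 2 gives 26300 nM, a step of a 3.3-fold higher number from compound 1 to compound 2 (0.52 log units; beyond the scatter). Compound 3 `O=S(=O)(NCCCNc1nccc(-c2[nH]c(-c3ccccc3)nc2-c2ccc(Cl)c(O)c2)n1)c1cccc(F)c1` differs from compound 1 in the core by chloro in place of fluoro on an aromatic carbon; in this assay compound 3 gives 33600 nM, a step of a 4.3-fold higher number from compound 1 to compound 3 (0.63 log units; beyond the scatter). Compound 4 `Cc1ccc(S(=O)(=O)NCCCNc2nccc(-c3[nH]c(-c4ccccc4)nc3-c3ccc(Cl)c(O)c3)n2)cc1` is unmeasured and relates to compound 3 by the same change, (4-methylphenyl in place of 3-fluorophenyl on a sulfonyl sulfur), at a place described in the same words as before. Among the measured compounds shown here, for compound 4 the step is expected to be about a 2.5-fold higher number from compound 3 to compound 4 (0.40 log units; beyond the scatter), resting on the single earlier step of a 3.3-fold higher number from compound 1 to compound 2 (0.52 log units; beyond the scatter) from compound 1 to compound 2. Compound 4 is therefore estimated at 85000 nM, with a range from 35000 nM to 200000 nM.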

Compound 4, half-maximal inhibitory concentration: 6020 nM
The estimate for compound 4 lay 14-fold (1.15 log units) above the measured number; the whole stated range lies above it.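

On the chloro core the sulfonyl change runs the opposite way (a 5.6-fold lower number from compound 3 to compound 4 (0.75 log units; beyond the scatter)), so in this assay its effect does not carry from one core to the other: the same change on two cores in this assay, a 3.3-fold higher number (0.52 log units; beyond the scatter) from compound 1 to compound 2 and a 5.6-fold lower number (0.75 log units; beyond the scatter) from compound 3 to compound 4, 19-fold (1.27 log units) apart, beyond the scatter of two such steps. The halogen change reverses in the same way once 4-methylphenyl sits on the sulfonyl sulfur (a 4.4-fold lower number from compound 2 to compound 4 (0.64 log units; beyond the scatter)): the same change on two cores in this assay, a 4.3-fold higher number (0.63 log units; beyond the scatter) from compound 1 to compound 3 and a 4.4-fold lower number (0.64 log units; beyond the scatter) from compound 2 to compound 4, 19-fold (1.27 log units) apart, beyond the scatter of two such steps. The two changes therefore do not add independently across these four compounds, but a single pair on each core does not show why, or which direction would hold for other sulfonyl groups.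

Still open, from the compounds shown here alone, is how an amine or a longer alkyl chain on the sulfonyl sulfur would behave on either core. Going by these compounds, whether bromo in place of chloro on the aromatic carbon would follow the same reversal also remains unknown.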